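Cytotoxicity Limits Across Three Biaryl Amide Analogues

A few compounds are considered here, and "the series" means these few. Any claim that something is new, unique, unknown or untested is made for them only; others in the source may bear on it.

Compound 1, `CCOC(=O)CCCCCOc1cccc(CN(C(=O)c2ccc(-c3cccc4ccccc34)cc2)C(C)C)c1`, in an ADME assay on BJ cells (Homo sapiens) for cytotoxicity, read by CellTiter-Glo and resazurin assay, with a stated time of 72 h (a higher number here means that more compound is needed for the effect, a lower number that less compound is needed), gives > 26000 nM, a limit of the assay.
Compound 2, `CCOC(=O)CCCCCOc1cccc(CN(C(=O)c2ccc(-c3ccoc3)cc2)C(C)C)c1`, in this assay gives > 26000 nM, a limit of the assay.
Compound 3, `CCOC(=O)CCCCCOc1cccc(CN(C(=O)c2ccc(-c3cccc(OC(C)C)c3)cc2)C(C)C)c1`, in this assay gives > 26000 nM, a limit of the assay.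

Compound 3 thus stands at the same limit as every other value shown (the limit of > 26000 nM in this assay, at which 3 of the 3 values shown sit), so no number places it above or below its neighbours. Compound 4, `CCOC(=O)CCCCCOc1cccc(CN(C(=O)c2ccc(-c3cc(OC)cc(OC)c3)cc2)C(C)C)c1`, differs from compound 3 by 3,5-dimethoxyphenyl in place of 3-isopropoxyphenyl on an aromatic carbon. The steps that touch compound 3 are a step that the two limits leave unreadable from compound 1 to compound 3 and a step that the two limits leave unreadable from compound 2 to compound 3; the remaining step, a step that the two limits leave unreadable from compound 1 to compound 2, is equally unreadable. For the measured compounds named here, no measured step therefore offers a size or a direction for this change. Compound 4 is expected to remain at the limit, with an expected step that the limit leaves unreadable from compound 3 to compound 4 that is none beyond the scatter. The estimate for compound 4 is 40000 nM, with a range from 20000 nM to 100000 nM.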

Compound 4, half-maximal effective concentration: > 26000 nM
Compound 4 was reported as a limit; the forecaster's own chance of this, stated with the estimate: 90%; the middle value lies beyond the limit too.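

Compound 4 sits at the same limit as compounds 1, 2 and 3, so no step among the four can be read: the limit of > 26000 nM in this assay, at which 4 of the 4 values shown sit.

As far as these compounds go, whether swapping this one group changes the concentration needed for the effect in this assay remains open.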